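Swapping a Pentyl Chain for a Cyclohexyl-Bearing Alkene

The source may report more compounds than this note shows. Statements on the series, on what has been measured and on what is new or still open speak of the compounds shown alone.

Compound 1 `CC(C(=O)NCc1ccc(C(F)(F)F)nc1Cl)c1ccc(NS(C)(=O)=O)c(F)c1`: 0.2 nM
Compound 2 `CCCCCc1nc(C(F)(F)F)ccc1CNC(=O)C(C)c1ccc(NS(C)(=O)=O)c(F)c1`: 1 nM
Compound 3 `CCC1CC=C(c2nc(C(F)(F)F)ccc2CNC(=O)C(C)c2ccc(NS(C)(=O)=O)c(F)c2)CC1`: 0.1 nM

In an assay on CHO cells for antagonist activity at transient receptor potential cation channel subfamily V member 1 (Homo sapiens), read by FLIPR and calcium flux (on this read-out higher numbers stand for weaker inhibition and lower numbers for stronger inhibition), compound 2 gives the highest of the three numbers, that is the weakest inhibition: a 5.0-fold higher number from compound 1 to compound 2 (0.70 log units; beyond the scatter), and a 10-fold lower number from compound 2 to compound 3 (1.00 log units; beyond the scatter). Compound 4 `CC(C(=O)NCc1ccc(C(F)(F)F)nc1/C=C/C1CCCCC1)c1ccc(NS(C)(=O)=O)c(F)c1` differs from compound 2 in one place: 2-cyclohexylethenyl in place of pentyl on an aromatic carbon. The step that bears most on this change is the one in which pentyl gave way to another six-membered carbon ring carrying an unsaturation, a 10-fold lower number from compound 2 to compound 3 (1.00 log units; beyond the scatter), a modest move to stronger inhibition. The step of a 2.0-fold lower number from compound 1 to compound 3 (0.30 log units; within the scatter) lay within the scatter, so ring-bearing groups here have sat near the small chloro. A downward step beyond the scatter is therefore expected, a 5.0-fold lower number from compound 2 to compound 4 (0.70 log units; beyond the scatter), and compound 4 is estimated at 0.2 nM, between 0.05 nM and 0.8 nM.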

Compound 4, inhibition constant: 0.7 nM
Compound 4: middle estimate off by 3.5-fold (0.54 log units), on the low side; low and high end bracket the measured number.
By their numbers in this assay, from the lowest: compounds 3 and 1 (each within the scatter of the next); then compounds 4 and 2 (each within the scatter of the next).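

In this assay a ring on this carbon is not enough on its own: 2-cyclohexylethenyl cannot be told apart from pentyl (a 1.4-fold lower number from compound 2 to compound 4 (0.15 log units; within the scatter)). Two groups that each carry a six-membered carbon ring and a double bond can still differ (a 7.0-fold higher number from compound 3 to compound 4 (0.85 log units; beyond the scatter)), and the small chloro also gives stronger inhibition than the new group (a 3.5-fold higher number from compound 1 to compound 4 (0.54 log units; beyond the scatter)). Nothing measured here explains these differences. As far as these compounds go, whether the double bond itself matters remains open, and so does how a saturated 2-cyclohexylethyl group or a phenyl ring would compare on this carbon.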